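The source may hold more compounds than are shown below. What is called first, only, known or untested is meant among the compounds shown, and "the series" means these compounds.

Compounds in this series share one core and differ in the groups around it. In a functional assay on HepG2 cells (Homo sapiens) for antiproliferative activity, read by MTT assay, with a stated time of 24 h (a lower number here means a stronger inhibitor, a higher number a weaker inhibitor), compound 3 `O=S(=O)(c1ccc(Br)cc1)n1c(-c2cn(-c3ccccc3)nc2-c2ccc(F)cc2)nc2ccccc21` gives 2550 nM. This lies within the usual scatter of the value for compound 1 `Cc1ccc(-c2nn(-c3ccccc3)cc2-c2nc3ccccc3n2S(=O)(=O)c2ccc(C(F)(F)F)cc2)cc1`, which is 1930 nM. Compound 2 `Cc1ccc(C)c(S(=O)(=O)n2c(-c3cn(-c4ccccc4)nc3-c3ccc(F)cc3)nc3ccccc32)c1` stands apart at 410 nM. Placing 4-bromophenyl instead of 2,5-dimethylphenyl on the sulfonyl sulfur gave a 6.2-fold higher number from compound 2 to compound 3 (0.79 log units; beyond the scatter).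

Compound 4 `O=S(=O)(c1ccc(C(F)(F)F)cc1)n1c(-c2cn(-c3ccccc3)nc2-c2ccc(F)cc2)nc2ccccc21` alters that same group of compound 3, with trifluoromethyl in place of bromo on an aromatic carbon, para to a large group (trifluoromethyl in place of bromo on an aromatic carbon). The measured step shows that this part of the molecule can shift the number, but it involved a different pair of groups and sets no size for this swap. The closest guide differs from compound 4 elsewhere but already carries 4-(trifluoromethyl)phenyl on the sulfonyl sulfur: it is compound 1, which gives 1930 nM. No change beyond the scatter is therefore expected in this assay, and the estimated step is a 1.3-fold lower number from compound 3 to compound 4 (0.11 log units; within the scatter). For compound 4 the estimate is 2000 nM, with an expected range from 800 nM to 5000 nM.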

Compound 4, half-maximal inhibitory concentration: 1680 nM
The estimate for compound 4 lay 1.2-fold (0.08 log units) above the measured number; low and high end bracket the measured number.
By their numbers in this assay, from the lowest: compound 2; then compounds 4, 1 and 3 (each within the scatter of the next).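

In this assay, trifluoromethyl in place of bromo gives a 1.5-fold lower number from compound 3 to compound 4 (0.18 log units; within the scatter), so this assay does not separate these two groups at this place on the ring. A change elsewhere in the molecule, fluoro in place of methyl, gives a 1.1-fold lower number from compound 1 to compound 4 (0.06 log units; within the scatter), so that swap does not separate compounds carrying 4-(trifluoromethyl)phenyl on the sulfonyl sulfur either. The gap to 2,5-dimethylphenyl remains, with a 4.1-fold higher number from compound 2 to compound 4 (0.61 log units; beyond the scatter), so both 4-bromophenyl in compound 3 and 4-(trifluoromethyl)phenyl in compound 4 sit beyond the scatter from that group.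

No measurement shown here explains this gap. On these data alone, it also remains open how an amine or a carboxylic acid on that same aromatic carbon would compare with bromo and trifluoromethyl.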